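A few compounds are considered here, and "the series" means these few. Any claim that something is new, unique, unknown or untested is made for them only; others in the source may bear on it.

In an ADME assay on SH-SY5Y cells (Homo sapiens) for cytotoxicity, read by MTT assay, with a stated time of 48 h (on this read-out higher numbers stand for weaker inhibition and lower numbers for stronger inhibition), compound 1 (`COc1ccc(C(=O)/C=C/c2ccc(C(=O)N3CCCCC3)cc2)c(O)c1`) is reported only as a limit, > 100000 nM. Compound 2 (`CCOCCOc1ccc(/C=C/C(=O)c2ccc(OC)cc2O)cc1`) likewise gives only a limit, > 100000 nM. Compound 3 (`COc1ccc(C(=O)/C=C/c2ccc(C(=O)NC(C)C)cc2)c(O)c1`) also gives only a limit, > 100000 nM. It therefore stands with the others at the limit of > 100000 nM in this assay, at which 3 of the 3 values shown sit. Compound 4 (`COc1ccc(C(=O)/C=C/c2ccc(OCc3ccccc3)cc2)c(O)c1`) carries benzyloxy in place of isopropylcarbamoyl on an aromatic carbon, para to a large group: benzyloxy in place of isopropylcarbamoyl on an aromatic carbon. Two measured changes at that place bear on this one: a step that the two limits leave unreadable from compound 1 to compound 2 and a step that the two limits leave unreadable from compound 2 to compound 3. Neither has a size that can be carried over, so no clear change is expected in this assay. The estimated change is a number no higher from compound 3 to compound 4 (the limit leaves the size open), with no direction expected beyond the scatter. In this assay the expected value for compound 4 is 100000 nM, with an estimated range of 40000 nM to 200000 nM.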

Compound 4, half-maximal inhibitory concentration: > 100000 nM
Compound 4 was reported as a limit; the forecaster's own chance of this, stated with the estimate: 75%; the middle value sits exactly at the limit.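

In this assay, among these compounds, compound 4 gives > 100000 nM, a limit, and no step to it from compound 1, compound 2 or compound 3 can be read. The compounds shown leave open whether exchanging these groups changes the cytotoxicity at all.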